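The source may report more compounds than this note shows. Statements on the series, on what has been measured and on what is new or still open speak of the compounds shown alone.

Working notes on the series, all on the shared core. In an ADME assay on J774.A1 cells (Mus musculus) for cytotoxicity, read by fluorescence and resazurin assay, with a stated time of 24 h (a lower number here means a stronger inhibitor, a higher number a weaker inhibitor), compound 3 (`CCOC(=O)c1c(C(C)C)oc2nc(N3CCCC3)ccc12`) gives > 330000 nM as a limit of the assay and not a number. In this assay compound 1 (`CCOC(=O)c1c(C)oc2nc(N3CCN(c4ccccc4)CC3)ccc12`) stands as "not determined" (no result reported) and compound 2 (`CNC(=O)c1c(C(C)C)oc2nc(N3CCCC3)ccc12`) as "not determined" (no result reported) so neither offers a number. Going by the values given here, compound 3 is therefore the only reading, and no measured step is available to size a change.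

Compound 4 (`CCOC(=O)c1c(C)oc2nc(N3CCCC3)ccc12`) differs from compound 3 by methyl in place of isopropyl on an aromatic carbon, next to the ring oxygen and next to the ring atom that bears an ethoxycarbonyl group (methyl in place of isopropyl on an aromatic carbon).

With compound 3 at > 330000 nM as the only anchor, no shift beyond the usual scatter is expected in this assay and no direction can be assigned. Another limit reading is a likely outcome. The expected change is a number no higher from compound 3 to compound 4 (the limit leaves the size open) as estimated here. For compound 4 the estimated value is 330000 nM with an expected range from 120000 nM to 700000 nM around it.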

Compound 4, half-maximal inhibitory concentration: 196000 nM
Estimate against measurement, compound 4: 1.7-fold (0.23 log units) above; the measured number falls inside the stated range.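

In this assay, going by these compounds alone, compound 4 gives 196000 nM, the first reading that is a number and not a limit of the assay. Methyl in place of isopropyl on this aromatic carbon, next to the ring oxygen, therefore gives an at least 1.6-fold lower number from compound 3 to compound 4 (0.22 log units; that floor lies within the scatter), so the change brings the reading inside the measurable range without yet showing a shift beyond the scatter. The step is only a floor, and its true size stays open because one end of it rests on a limit: the limit of > 330000 nM in this assay, at which 1 of the 4 values shown sits.

Open, going by these compounds, is how an ethyl group or a bare hydrogen on this carbon would read in this assay, and whether a carboxylic acid in place of the ethoxycarbonyl group would move the number. A single step at one position supports no trend across the series.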